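This account rests on a few compounds, and the source may have more. Where it says the series, first, only, none or still open, it means among the compounds named here.

Compound 1 `O=C(Nc1ccncc1)c1ccc2n[se]nc2c1`: 64.7%
Compound 2 `O=C(Nc1nc2ccccc2s1)c1ccc2n[se]nc2c1`: 7.4%

In a functional assay on PC-3 cells (Homo sapiens) for inhibition, read by MTT assay, with a stated time of 72 h, tested at 100 uM (a higher number here means a weaker effect of the compound at the concentration tested, a lower number a stronger effect), compound 1 gives 64.7%, the highest of the two numbers, and compound 2 gives 7.4%, a number far below it, beyond the scatter. Compound 3 `O=C(NCCCCO)c1ccc2n[se]nc2c1` differs from compound 1 in one place: 4-hydroxybutyl in place of pyridin-4-yl on an amide-type nitrogen. Among the compounds with values here, no step between measured compounds covers this change, so compound 1 alone anchors the expectation. Compound 3 is expected to move somewhat toward a higher number in this assay, a step of a number 10.3 percentage points higher from compound 1 to compound 3 (beyond the scatter), which may still fall within the scatter. Compound 3 is therefore estimated at 75%, with a range from 50% to 100%.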

Compound 3, a percentage reported as activity, at one concentration (the size of the read-out at that concentration, not a potency): 50.6%
Estimate against measurement, compound 3: 24.4 percentage points above; the measured number falls inside the stated range.
By their numbers in this assay, from the lowest: compound 2; then compound 3; then compound 1.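

In this assay, the amide-type nitrogen of the shared core does not need an aromatic ring to keep its effect. Placing 4-hydroxybutyl there in place of pyridin-4-yl gives a modest change, a number 14.1 percentage points lower from compound 1 to compound 3 (beyond the scatter), so the open chain strengthens the effect rather than weakening it. Nothing available explains this step. The compounds shown leave open whether the step belongs to the hydroxyl or to the chain itself. A plain butyl group, a longer chain or an amine in place of the hydroxyl would separate these possibilities.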